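The compounds below may be only part of what the source reports. "The series", "measured", "known", "first", "only" and "open" are said of these compounds alone.

Measured compounds:
- compound 1 `Cc1ccc(-c2cc(Cl)ccc2CCCCCC[C@@H](O)C[C@](O)(CC(=O)O)C(=O)O)cc1` gives 2700 nM
- compound 2 `O=C(O)C[C@@](O)(C[C@H](O)CCCCCn1ccc2cc(Cl)ccc21)C(=O)O` gives 3500 nM
- compound 3 `O=C(O)C[C@@](O)(C[C@H](O)CCCCCn1c(-c2ccccc2)cc2cc(Cl)ccc21)C(=O)O` gives 370 nM

All three were tested in an assay on isolated protein for inhibition of ATP-citrate synthase (Homo sapiens); on this read-out higher numbers stand for weaker inhibition and lower numbers for stronger inhibition. Among them compound 3 stands lowest, and so is the strongest inhibitor of the set: compound 1 sits a step above it, and compound 2 sits furthest away. Within the data shown here, the one single-point step that was measured, a 9.5-fold lower number from compound 2 to compound 3 (0.98 log units; beyond the scatter), shows what a phenyl on that aromatic carbon of the shared core is worth when it replaces a hydrogen.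

Compound 4 `Cc1cc2cc(Cl)ccc2n1CCCCC[C@@H](O)C[C@](O)(CC(=O)O)C(=O)O` has not yet been measured. It differs from compound 3 in one place: methyl in place of phenyl on an aromatic carbon. Among the measured compounds shown here, the only step that bears on this change is the phenyl-for-hydrogen step, since methyl lies between hydrogen and phenyl in size, with no ring at all. Removing the phenyl would be expected to give back a good part of the gain seen in a 9.5-fold lower number from compound 2 to compound 3 (0.98 log units; beyond the scatter), while the methyl that enters may keep some of it. The expected outcome is therefore a higher number than for compound 3, but one that stays below compound 2. The step expected is a 4.1-fold higher number from compound 3 to compound 4 (0.61 log units; beyond the scatter). For compound 4 the estimate in this assay is 1500 nM, with a likely range from 500 nM to 4500 nM.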

Compound 4, inhibition constant: 13000 nM
For compound 4 the middle estimate is 8.7-fold (0.94 log units) below the measured one; measured number outside the range, above it.
By their numbers in this assay, from the lowest: compound 3; then compounds 1 and 2 (each within the scatter of the next); then compound 4.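

In this assay, the group on this aromatic carbon, next to the ring nitrogen, does not act like a simple scale running from hydrogen through methyl to phenyl. Exchanging the phenyl for methyl gives a 35-fold higher number from compound 3 to compound 4 (1.55 log units; beyond the scatter) and so loses far more than the phenyl's own gain over hydrogen, while the comparison with hydrogen gives a 3.7-fold higher number from compound 2 to compound 4 (0.57 log units; beyond the scatter) and shows that the methyl is no halfway point: among these three groups, inhibition is weakest with methyl and strongest with phenyl, and a small carbon group on this position is worse than none. No measurement at hand explains why the methyl gives this result.

These three groups leave open whether an ethyl, a cyclohexyl or a pyridine ring on this carbon would behave like the methyl or like the phenyl, so it cannot yet be said whether an aromatic ring is needed or a larger group of any shape would serve. Also open, going by these compounds, is whether a fluorine or a methoxy group on the phenyl would lower the number further.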